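A halogen swap on the carbonyl of compound 2

A few compounds are considered here, and "the series" means these few. Any claim that something is new, unique, unknown or untested is made for them only; others in the source may bear on it.

In a functional assay on A549 cells (Homo sapiens) for antiproliferative activity, read by MTT assay, with a stated time of 24 h (a lower number here means a stronger inhibitor, a higher number a weaker inhibitor), compound 1 (`Cc1cccc(NNC(=O)c2cccc(NS(=O)(=O)c3cnc(O)nc3O)c2)c1`) reads > 20000 nM, which is a limit of the assay and not a number. For the measured compounds named here, compound 2 (`O=C(NNC(=O)c1cccc(NS(=O)(=O)c2cnc(O)nc2O)c1)c1cccc(Cl)c1`) gives 6000 nM, the only true number so far. Going by the values given here, the single measured step, an at least 3.3-fold lower number from compound 1 to compound 2 (0.52 log units; beyond the scatter), changes a different group, so it sets no size for what follows. Compound 3 (`O=C(NNC(=O)c1cccc(NS(=O)(=O)c2cnc(O)nc2O)c1)c1ccc(F)cc1`) differs from compound 2 thus: 4-fluorophenyl in place of 3-chlorophenyl on a carbonyl carbon, with 4-fluorophenyl in place of 3-chlorophenyl on a carbonyl carbon. The expected change, a 1.2-fold higher number from compound 2 to compound 3 (0.07 log units; within the scatter), is none beyond the scatter. Compound 3 is estimated at 7000 nM, within 2500 nM to 18000 nM.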

Compound 3, half-maximal inhibitory concentration: > 20000 nM
Compound 3 was reported as a limit (the forecaster's own chance of this, stated with the estimate: 15%); middle value at least 2.8-fold (0.45 log units) away from the limit.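

Changing 3-chlorophenyl to 4-fluorophenyl on a carbonyl carbon matters in this assay, giving an at least 3.3-fold higher number from compound 2 to compound 3 (0.52 log units; beyond the scatter). The earlier step showed only a change from 3-methylphenyl to a carbonyl-linked group, whereas this one keeps the carbonyl and changes only the aromatic group, so the response here comes from that group alone. The step between compound 1 and compound 3 cannot be read, because both values are limits: the limit of > 20000 nM in this assay, at which 2 of the 3 values shown sit.

On these data alone, whether the halogen or its place on the ring matters more stays open. A 3-fluorophenyl or 4-chlorophenyl group would separate the two.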